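Dichlorophenyl isomers on the hydrazone nitrogen

A few compounds are considered here, and "the series" means these few. Any claim that something is new, unique, unknown or untested is made for them only; others in the source may bear on it.

The series shares the core seen in compound 1 `Cc1cccc(C)c1NN=C1CCC(C)n2c1ncc(C(=O)O)c2=O`, which in a functional assay on the whole organism with Rattus norvegicus as the target (on this read-out lower numbers stand for an effect already at smaller amounts and higher numbers for an effect only at larger amounts of compound), gives 320 umol/kg. Compound 2 `CC1CCC(=NNc2ccc(Cl)cc2Cl)c2ncc(C(=O)O)c(=O)n21` carries a 2,4-dichlorophenyl in place of the 2,6-dimethylphenyl. For compound 2 this assay reports only a limit, > 100 umol/kg, so compound 2 stands at the edge of the measured range without a number of its own. The step that the limit leaves unreadable from compound 1 to compound 2 is accordingly unreadable, which rests on (the limit of > 100 umol/kg in this assay, at which 1 of the 2 values shown sits).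

Compound 3 `CC1CCC(=NNc2ccc(Cl)c(Cl)c2)c2ncc(C(=O)O)c(=O)n21` is the next member: 3,4-dichlorophenyl in place of 2,4-dichlorophenyl on an amine nitrogen. Within the data shown here, no measured step goes from one dichlorophenyl to another; the only step in hand, from compound 1 to compound 2, is unreadable and concerns a different group. The data therefore give no ground for expecting a step in this assay beyond the scatter in either direction. Compound 3 is expected to give about 300 umol/kg, within a range from 100 umol/kg to 1000 umol/kg. The estimated step that the limit leaves unreadable from compound 2 to compound 3 is one of no change beyond the scatter, and a further limit for compound 3 is a real possibility.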

Compound 3, dose for 50% inhibition: > 100 umol/kg
Compound 3 was reported as a limit (the forecaster's own chance of this, stated with the estimate: 60%); the middle value lies beyond the limit too.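

In this assay compound 3 gives > 100 umol/kg, which is a limit and not a number. No step can be read among compound 1, compound 2 and compound 3: the limit of > 100 umol/kg in this assay, at which 2 of the 3 values shown sit. The compounds shown leave open whether the 2,4-dichlorophenyl and 3,4-dichlorophenyl groups differ from each other, or from the 2,6-dimethylphenyl group, in this assay.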